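Replacing the Thiadiazole Sulfur Group with a Piperazine Chain

This account rests on a few compounds, and the source may have more. Where it says the series, first, only, none or still open, it means among the compounds named here.

Three compounds have been measured in a functional assay on MCF7 cells (Homo sapiens) for cytotoxicity, read by MTT assay, with a stated time of 24 h, tested at 16 ug/mL; on this read-out lower numbers stand for a weaker effect and higher numbers for a stronger effect at the one concentration tested:
compound 1, `Cn1c(-c2ccc(NC(=O)CCl)cc2)nc(-c2ccccc2)c1-c1ccccc1`, gives 15.2%
compound 2, `Cn1nnnc1SCC(=O)Nc1ccc(-c2nc(-c3ccccc3)c(-c3ccccc3)n2C)cc1`, gives 63.7%
compound 3, `Cc1nnc(SCC(=O)Nc2ccc(-c3nc(-c4ccccc4)c(-c4ccccc4)n3C)cc2)s1`, gives 74.9%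

Compound 3 stands highest of the three, with a number 11.2 percentage points higher from compound 2 to compound 3 (beyond the scatter) and a number 59.7 percentage points higher from compound 1 to compound 3 (beyond the scatter). Compound 4 is `CN(C)/C=C/N1CCN(CC(=O)Nc2ccc(-c3nc(-c4ccccc4)c(-c4ccccc4)n3C)cc2)CC1`. The change is: 4-(2-(dimethylamino)ethenyl)piperazin-1-yl in place of (5-methyl-1,3,4-thiadiazol-2-yl)sulfanyl on a saturated chain carbon bound to a carbonyl carbon.

All measured steps concern the same place. Both a number 48.5 percentage points higher from compound 1 to compound 2 (beyond the scatter) and a number 59.7 percentage points higher from compound 1 to compound 3 (beyond the scatter) show a large rise when a sulfur-linked five-membered aromatic ring replaces chloro, and a number 11.2 percentage points higher from compound 2 to compound 3 (beyond the scatter) is a modest shift between two such rings. Going by the values given here, no step involves a piperazinyl group or a group without sulfur, so the direction for compound 4 is uncertain. Compound 4 is expected to fall somewhat below compound 3, a number 24.9 percentage points lower from compound 3 to compound 4 (beyond the scatter), with an estimated 50% in a range from 20% to 80%.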

Compound 4, a percentage reported as activity, at one concentration (the size of the read-out at that concentration, not a potency): 19.4%
Compound 4: middle estimate off by 30.6 percentage points, on the high side; the whole stated range lies above it.
By their numbers in this assay, from the lowest: compounds 1 and 4 (each within the scatter of the next); then compound 2; then compound 3.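

In this assay, the gain from a sulfur-linked five-membered aromatic ring on this saturated chain carbon does not carry over to a sulfur-free piperazine group: a number 55.5 percentage points lower from compound 3 to compound 4 (beyond the scatter) and a number 44.3 percentage points lower from compound 2 to compound 4 (beyond the scatter) together show that loss. With a number 4.2 percentage points higher from compound 1 to compound 4 (within the scatter) as the remaining step, the much larger 4-(2-(dimethylamino)ethenyl)piperazin-1-yl group reads like plain chloro. No evidence at hand explains this. Still open, as far as these compounds go, is whether a simple dimethylamino group, an unsubstituted piperazine or a phenylsulfanyl group would behave the same way here, and so whether the sulfur or the aromatic ring matters more.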